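Losing the nitro group on the pyrazoline aryl ring

A few compounds are considered here, and "the series" means these few. Any claim that something is new, unique, unknown or untested is made for them only; others in the source may bear on it.

Compound 1 `COc1cc(C2CC(c3ccc([N+](=O)[O-])cc3)=NN2C(C)=O)ccc1OCc1cn(Cc2ccc([N+](=O)[O-])cc2)nn1`: 85%
Compound 2 `COc1ccc(C2CC(c3ccc(OCc4cn(Cc5ccc([N+](=O)[O-])cc5)nn4)cc3)=NN2C(C)=O)cc1`: 37%

Both measured compounds were tested in a functional assay on COLO 205 cells (Homo sapiens) for inhibition, read by sulforhodamine B assay, tested at 100 uM; on this read-out higher numbers stand for more inhibition of growth at the one concentration tested and lower numbers for less inhibition of growth. Compound 1 gives 85% and stands highest of the two numbers here; compound 2 gives 37%, a number well beyond the scatter below it. The two structures differ in more than one place, so their values only show that the arrangement in compound 1 is the stronger of the pair.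

Compound 3 `COc1cc(C2CC(c3ccccc3)=NN2C(C)=O)ccc1OCc1cn(Cc2ccc([N+](=O)[O-])cc2)nn1` is not yet measured. It differs from compound 1 in one place: hydrogen in place of nitro on an aromatic carbon. Among the compounds with values here, no step between measured compounds reflects this change on its own, so its effect is uncertain.

Compound 3 is expected to keep much of the activity of compound 1 but to fall off moderately, an estimated step of a number 25 percentage points lower from compound 1 to compound 3 (beyond the scatter) in this assay. The estimate for compound 3 is 60%, with a range from 30% to 85%.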

Compound 3, percent growth inhibition at one concentration: 11%
Compound 3: middle estimate off by 49 percentage points, on the high side; measured number below the stated range.
By their numbers in this assay, from the lowest: compound 3; then compound 2; then compound 1.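

In this assay, hydrogen in place of nitro gives a number 74 percentage points lower from compound 1 to compound 3 (beyond the scatter), a large step. Within the data shown here, this is the first comparison here that changes one place alone, so the whole step belongs to the move from 4-nitrophenyl to phenyl, and the nitro group that remains elsewhere in compound 3 does not keep the number high on its own. Nothing measured here explains why this one group matters so much.

On these data alone, it remains open whether nitro itself is needed at this place or whether another group there, such as an amino group, a nitrile or a carboxylic acid, would restore the growth inhibition of compound 1. The lower number of compound 2 also cannot be tied to any one change, since that compound differs from compound 1 in more than one place.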